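The compounds below may be only part of what the source reports. "The series", "measured", "known", "first", "only" and "open" are said of these compounds alone.

Measured so far in a functional assay on A549 cells (Homo sapiens) for cytotoxicity, read by MTT assay, with a stated time of 72 h; a lower number here means a stronger inhibitor, a higher number a weaker inhibitor:
- compound 1 `O=C(N/N=C/c1ccc(F)cc1)Nc1cc2c(Nc3ccc(F)c(Cl)c3)ncnc2cc1O[C@H]1CCOC1`: 35100 nM
- compound 2 `O=C(N/N=C/c1ccc([N+](=O)[O-])cc1)Nc1cc2c(Nc3ccc(F)c(Cl)c3)ncnc2cc1O[C@H]1CCOC1`: 31200 nM
- compound 3 `COc1ccc(/C=N/NC(=O)Nc2cc3c(Nc4ccc(F)c(Cl)c4)ncnc3cc2O[C@H]2CCOC2)c(OC)c1OC`: 25200 nM

These compounds share one core and differ only in the aromatic group on a carbon with a double bond to nitrogen. Compound 3 cannot be separated from the other two on these numbers. The comparisons with it are a 1.4-fold lower number from compound 1 to compound 3 (0.14 log units; within the scatter) and a 1.2-fold lower number from compound 2 to compound 3 (0.09 log units; within the scatter).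

The next compound to test is compound 4 `O=C(N/N=C/c1cc(Br)c(O)c(Br)c1)Nc1cc2c(Nc3ccc(F)c(Cl)c3)ncnc2cc1O[C@H]1CCOC1`. It has 3,5-dibromo-4-hydroxyphenyl in place of 2,3,4-trimethoxyphenyl at that same carbon, a change counted as 3,5-dibromo-4-hydroxyphenyl in place of 2,3,4-trimethoxyphenyl on a carbon with a double bond to nitrogen.

The measured steps at this carbon are the best available guide. Besides the two comparisons above, there is a 1.1-fold lower number from compound 1 to compound 2 (0.05 log units; within the scatter). All three swaps of this group left the number in this assay essentially unmoved, and the same may hold for the new group. However, no measured compound carries bromine or a hydroxy group on this ring, so the guide is incomplete and the range should stay wide.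

The expected change is small, and the estimate is a 1.1-fold lower number from compound 3 to compound 4 (0.04 log units; within the scatter). For compound 4 the estimated value is 23000 nM, with an expected range of 10000 nM to 45000 nM.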

Compound 4, half-maximal inhibitory concentration: 8910 nM
Compound 4: the middle estimate sits 2.6-fold (0.41 log units) above what was measured, and the stated range ends above it.
By their numbers in this assay, from the lowest: compound 4; then compounds 3, 2 and 1 (each within the scatter of the next).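

The aromatic group on a carbon with a double bond to nitrogen is not as silent in this assay as the first three compounds suggested: the swaps among them stayed within the scatter, while 3,5-dibromo-4-hydroxyphenyl gives a modest but real shift in all three comparisons (a 2.8-fold lower number from compound 3 to compound 4 (0.45 log units; beyond the scatter); a 3.5-fold lower number from compound 2 to compound 4 (0.54 log units; beyond the scatter); a 3.9-fold lower number from compound 1 to compound 4 (0.60 log units; beyond the scatter)). Compound 4 is therefore the strongest inhibitor of the four in this assay, and its steps to the fluoro, nitro and trimethoxy compounds are of similar size, so the gain does not depend on which of those three groups it is compared with. Nothing available here explains why this group shifts the number, and no measurement of any property or of the compounds' behaviour in cells accompanies the result.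

The new group brings bromine and a hydroxy group together, so these compounds cannot show whether one of them alone accounts for the step or whether both are needed. Also open, as far as these compounds go, is how the number would respond to a phenyl ring carrying only a hydroxy group, only bromine atoms, or a different group such as an amine or a carboxylic acid.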